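Anilino variation on a shared pyrimidine-type core against melanoma cells

The source may hold more compounds than are shown below. What is called first, only, known or untested is meant among the compounds shown, and "the series" means these compounds.

Measured compounds:
compound 1 `C#CCSc1nc(Nc2ccc(OC)cc2)c(C#N)c(-c2ccccc2)n1`, 9710 nM
compound 2 `C#CCSc1nc(Nc2ccccc2Cl)c(C#N)c(-c2ccccc2)n1`, 12400 nM
compound 3 `COc1ccc(Nc2nc(SCc3cn(Cc4ccccc4Cl)nn3)nc(-c3ccccc3)c2C#N)cc1`, 3990 nM

In a functional assay on B16-F10 cells (Mus musculus) for inhibition, read by MTT assay, with a stated time of 72 h (a lower number here means a stronger inhibitor, a higher number a weaker inhibitor), compound 3 gives the lowest of the three numbers. Its nearest neighbour is compound 1, and compound 2 lies furthest away; both of those gaps are beyond the usual scatter, so compound 3 stands apart from the other two on the shared core.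

Compound 4 `Cc1cccc(Nc2nc(SCc3cn(Cc4ccccc4Cl)nn3)nc(-c3ccccc3)c2C#N)c1` has not yet been measured. It differs from compound 3 in one place: 3-methylphenyl in place of 4-methoxyphenyl on a nitrogen on an aromatic ring. Among the measured compounds shown here, the only measured step that bears on this position is the one from compound 1 to compound 2, where the aryl group on the same ring nitrogen was exchanged, and that step was a 1.3-fold higher number from compound 1 to compound 2 (0.11 log units; within the scatter). On that evidence a change of the aryl group at this nitrogen has so far moved this assay little, and a step of similar size, in no clear direction, is expected here; the account therefore expects a 1.1-fold higher number from compound 3 to compound 4 (0.05 log units; within the scatter).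

The estimate for compound 4 in this assay is accordingly 4500 nM, with an expected range from 2000 nM to 10000 nM.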

Compound 4, half-maximal inhibitory concentration: 13500 nM
Compound 4: middle estimate off by 3.0-fold (0.48 log units), on the low side; the measured number lies above the stated range.
By their numbers in this assay, from the lowest: compound 3; then compounds 1, 2 and 4 (each within the scatter of the next).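

The step of a 3.4-fold higher number from compound 3 to compound 4 (0.53 log units; beyond the scatter) shows that in this assay the aryl group on this nitrogen can matter, which the earlier step of a 1.3-fold higher number from compound 1 to compound 2 (0.11 log units; within the scatter) did not show, as that step stayed within the scatter and involved a different pair of groups on a different side chain. Exchanging 4-methoxyphenyl for 3-methylphenyl removes the advantage that set compound 3 apart, so its lowest number depends on the (4-methoxyphenyl)amino group as well as on the rest of the molecule, and the two earlier compounds gave no sign of this dependence. No measurement shown gives a reason for this step.

The change replaces the methoxy group with a methyl group and also alters the place given in the group's name, so the compounds shown leave open which of the two carries the step. They also leave open how this assay would read with a phenyl group carrying an amine or a carboxylic acid on the same nitrogen.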